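Fluorophenyl triazole amides: tolerance of fluorine position

This account rests on a few compounds, and the source may have more. Where it says the series, first, only, none or still open, it means among the compounds named here.

Measured compounds:
compound 1 `Cc1c(C(=O)Nc2ccc(Oc3ccnc4[nH]ccc34)c(F)c2)nnn1-c1ccccc1F` — 3240 nM
compound 2 `Cc1c(C(=O)Nc2ccc(Oc3ccnc4[nH]ccc34)c(F)c2)nnn1-c1ccc(F)cc1` — 4350 nM
compound 3 `Cc1c(C(=O)Nc2ccc(Oc3ccnc4[nH]ccc34)cc2)nnn1-c1ccccc1F` — 3450 nM

In a functional assay on PC-3 cells (Homo sapiens) for cytotoxicity, read by MTT assay, with a stated time of 72 h (on this read-out higher numbers stand for weaker inhibition and lower numbers for stronger inhibition), the three compounds give numbers that lie close together. From compound 1 to compound 2 the change is 4-fluorophenyl in place of 2-fluorophenyl on an aromatic nitrogen and the step is a 1.3-fold higher number from compound 1 to compound 2 (0.13 log units; within the scatter). The cores of compound 1 and compound 3 differ by hydrogen in place of fluoro on an aromatic carbon, with the step of a 1.1-fold higher number from compound 1 to compound 3 (0.03 log units; within the scatter).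

Compound 4 `Cc1c(C(=O)Nc2ccc(Oc3ccnc4[nH]ccc34)cc2)nnn1-c1ccc(F)cc1` is not yet measured. It differs from compound 3 by 4-fluorophenyl in place of 2-fluorophenyl on an aromatic nitrogen; this is the same change as from compound 1 to compound 2, made on the core of compound 3. The step from compound 3 to compound 4 is expected to be about a 1.3-fold higher number from compound 3 to compound 4 (0.12 log units; within the scatter) in this assay, because a 1.3-fold higher number from compound 1 to compound 2 (0.13 log units; within the scatter) was the size seen for this change on the core of compound 1. Compound 4 is therefore estimated at 4600 nM in this assay, expected between 2300 nM and 9000 nM.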

Compound 4, half-maximal inhibitory concentration: 3450 nM
The estimate for compound 4 lay 1.3-fold (0.12 log units) above the measured number, within the range that was stated.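

In this assay, 4-fluorophenyl in place of 2-fluorophenyl on the core of compound 3 gives no change at the digits printed from compound 3 to compound 4 (within the scatter), and this agrees with the same change on the core of compound 1: the same change on two cores in this assay, a 1.3-fold higher number (0.13 log units; within the scatter) from compound 1 to compound 2 and no change at the digits printed (within the scatter) from compound 3 to compound 4, 1.3-fold (0.13 log units) apart, within the scatter of two such steps

Hydrogen in place of fluoro on an aromatic carbon gives a 1.3-fold lower number from compound 2 to compound 4 (0.10 log units; within the scatter), which also agrees with its counterpart on the other core: the same change on two cores in this assay, a 1.1-fold higher number (0.03 log units; within the scatter) from compound 1 to compound 3 and a 1.3-fold lower number (0.10 log units; within the scatter) from compound 2 to compound 4, 1.3-fold (0.13 log units) apart, within the scatter of two such steps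

Among the compounds shown here, both changes carry between these cores without a detectable difference, but each step lies within the scatter, so this shows only that neither change has a measurable effect here, not that a real effect transfers from core to core.

From the compounds shown here alone, it remains open whether an amine or a carboxylic acid on the fluorophenyl group, or a longer chain in place of the methyl group, would give a step beyond the scatter. Going by these compounds, it is also open whether such a step would carry between the two cores.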